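Swapping the para group on the triazole-borne phenyl ring

The compounds below may be only part of what the source reports. "The series", "measured", "known", "first", "only" and "open" are said of these compounds alone.

Measured compounds:
- Compound 1 `N#CC1=C(N)Oc2c(N)cc3nc4ccccc4nc3c2C12C(=O)N(Cc1cnnn1-c1ccccc1Br)c1ccccc12`: in an ADME assay on HUVEC cells (Homo sapiens) for antiproliferative activity, read by MTT assay, with a stated time of 48 h (a higher number here means a weaker inhibitor, a lower number a stronger inhibitor), compound 1 gives 34200 nM.
- Compound 2 `CC(=O)Nc1ccc(-n2nncc2CN2C(=O)C3(C(C#N)=C(N)Oc4c(N)cc5nc6ccccc6nc5c43)c3ccccc32)cc1`: compound 2 gives only a limit of this assay, > 50000 nM.

Compound 2 therefore stands at the edge of what this assay can report, and only a limit is known for it. For the measured compounds named here, the one measured step that bears on this position is an at least 1.4-fold higher number from compound 1 to compound 2 (0.16 log units; that floor lies within the scatter), and that step rests on (the limit of > 50000 nM in this assay, at which 1 of the 2 values shown sits).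

Compound 3 `N#CC1=C(N)Oc2c(N)cc3nc4ccccc4nc3c2C12C(=O)N(Cc1cnnn1-c1ccc([N+](=O)[O-])cc1)c1ccccc12` differs from compound 2 in one place: nitro in place of acetamido on an aromatic carbon. Going by the values given here, both compounds carry a substituted phenyl on the same triazole nitrogen, and the only earlier step on that ring gave no movement beyond the scatter. Among the compounds with values here, no measured step tells how the nitro group itself behaves here. The expected step of an at least 1.1-fold lower number from compound 2 to compound 3 (0.04 log units; that floor lies within the scatter) is thus a weakening no larger than the scatter, and compound 3 is estimated at 45000 nM, within 20000 nM to 100000 nM.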

Compound 3, half-maximal inhibitory concentration: > 50000 nM
Compound 3: no number, only a limit (the forecaster's own chance of this, stated with the estimate: 50%); middle value at least 1.1-fold (0.04 log units) from the limit.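

In this assay compound 3 gives > 50000 nM, and this is a limit of the assay, not a number. For the compounds shown here, the step between compound 2 and compound 3 cannot be read, because both compounds rest on the same limit: the limit of > 50000 nM in this assay, at which 2 of the 3 values shown sit. The only readable step is an at least 1.4-fold higher number from compound 1 to compound 3 (0.16 log units; that floor lies within the scatter), so 4-nitrophenyl, like 4-acetamidophenyl, gives a result that cannot be told apart from that of 2-bromophenyl.

On these data alone, it stays open how far beyond the limit compound 2 and compound 3 lie, and whether any group on this phenyl ring can bring a measurable number. A 4-aminophenyl or 4-bromophenyl ring would help, the latter by separating the effect of the bromine itself from that of where the group sits on the ring.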